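Pyridin-4-yl in Place of Pyridin-3-yl: Expected Growth Inhibition

The source may report more compounds than this note shows. Statements on the series, on what has been measured and on what is new or still open speak of the compounds shown alone.

Measured compounds:
compound 1, `CS(=O)(=O)c1ccc(-c2cnc3[nH]cc(-c4nnc(-c5ccncc5)o4)c(=O)c3c2)cc1`: 5.61%
compound 2, `O=c1c(-c2nnc(-c3ccc(F)cc3)o2)c[nH]c2ncc(-c3cccnc3)cc12`: 11.1%
compound 3, `CS(=O)(=O)c1ccc(-c2cnc3[nH]cc(-c4nnc(-c5cccnc5)o4)c(=O)c3c2)cc1`: 9.26%

All three were tested in a functional assay on HCT-116 cells (Homo sapiens) for inhibition, read by MTT assay, with a stated time of 24 h, tested at 5 uM; on this read-out higher numbers stand for more inhibition of growth at the one concentration tested and lower numbers for less inhibition of growth. Compound 2 gives 11.1%, compound 3 gives 9.26% and compound 1 gives 5.61%; the three numbers lie within the scatter of one another. How the core of compound 2 differs from that of compound 3 is not broken down here.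

The step from compound 3 to compound 1 is the change (pyridin-4-yl in place of pyridin-3-yl on an aromatic carbon), and it made a number 3.7 percentage points lower from compound 3 to compound 1 (within the scatter). Compound 4, `O=c1c(-c2nnc(-c3ccc(F)cc3)o2)c[nH]c2ncc(-c3ccncc3)cc12`, not yet measured, arises from compound 2 by pyridin-4-yl in place of pyridin-3-yl on an aromatic carbon. This is the same kind of change, but not the same: in compound 1 the pyridin-4-yl sits next to the ring nitrogen and next to the ring oxygen of the five-membered ring, while in compound 4 it sits two atoms from the ring nitrogen of the six-membered ring, meta and para to a fused ring.

Because a number 3.7 percentage points lower from compound 3 to compound 1 (within the scatter) was small, a step of a number 3.1 percentage points lower from compound 2 to compound 4 (within the scatter) is expected. Compound 4 is estimated at 8% in this assay , between -2% and 20%.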

Compound 4, percent growth inhibition at one concentration: 10.9%
The estimate for compound 4 lay 2.9 percentage points below the measured number; the measured number falls inside the stated range.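

In this assay, pyridin-4-yl in place of pyridin-3-yl on the core of compound 2 gave a number 0.2 percentage points lower from compound 2 to compound 4 (within the scatter). Set beside the same change on the core of compound 3, the two steps do not differ: the same change on two cores in this assay, a number 3.7 percentage points lower (within the scatter) from compound 3 to compound 1 and a number 0.2 percentage points lower (within the scatter) from compound 2 to compound 4, 3.5 percentage points apart, within the scatter of two such steps. This shows that the change carried from one core to the other here without a step beyond the scatter on either, but it does not show that the change has no effect on growth inhibition, nor that it would read the same way on a third core, since two pairs at a single concentration cannot settle either point.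

The compounds shown leave open whether pyridin-2-yl, a plain phenyl or a morpholine in the same place would give a step beyond the scatter. As far as these compounds go, it also stays open whether the two pyridinyl groups would still read alike at higher concentrations than the one used in this assay.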